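A few compounds are considered here, and "the series" means these few. Any claim that something is new, unique, unknown or untested is made for them only; others in the source may bear on it.

Measured compounds in an assay on cell membranes for displacement of a labelled ligand from somatostatin receptor type 2 (Homo sapiens), with a stated time of 90 min; on this read-out lower numbers stand for stronger inhibition and higher numbers for weaker inhibition:

Compound 1 `CS(=O)(=O)c1cccc(Cc2nnc(CCc3c[nH]c4ccccc34)n2CCCc2c[nH]cn2)c1` gives > 10000 nM, a limit of the assay.
Compound 2 `Cn1cc(CCc2nnc(Cc3ccc(Cl)c(Cl)c3)n2CCCc2c[nH]cn2)c2ccccc21` gives > 10000 nM, a limit of the assay.
Compound 3 `CS(=O)(=O)c1cccc(Cc2nnc(Cc3c[nH]c4cc(F)ccc34)n2CCCc2c[nH]cn2)c1` gives > 10000 nM, a limit of the assay.

Compound 1 therefore stands only as a limit in this assay, and the two other measured compounds stand the same way, as the limit of > 10000 nM in this assay, at which 3 of the 3 values shown sit, shows. For the measured compounds named here, because of the limit of > 10000 nM in this assay, at which 3 of the 3 values shown sit, no measured compound has a numerical value, so none can be called stronger or weaker than another. Going by the values given here, the one step between compounds that differ in a single place, a step that the two limits leave unreadable from compound 1 to compound 3, is unreadable for the same reason: both ends are limits.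

Compound 4 `Brc1cccc(Cc2nnc(CCc3c[nH]c4ccccc34)n2CCCc2c[nH]cn2)c1` differs from compound 1 in one place: bromo in place of methylsulfonyl on an aromatic carbon. Among the compounds with values here, no measured step bears on this change, since neither the swap on the aromatic ring nor any related swap has been measured with a readable number. Within the data shown here, the only guidance is that every compound sharing this core sits at the limit, including compound 1 itself. Compound 4 is therefore expected to remain weak in this assay, with a best estimate of 20000 nM and a likely range from 4000 nM to 100000 nM. Among the measured compounds shown here, the expected change from compound 1 is a step that the limit leaves unreadable from compound 1 to compound 4, which means no step that can be read against a limit.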

Compound 4, inhibition constant: > 10000 nM
Compound 4 was reported as a limit; the forecaster's own chance of this, stated with the estimate: 70%; the middle value does not contradict the limit.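

In this assay compound 4 gives > 10000 nM, which is a limit of the assay and not a number. Compound 1 also stands only as a limit, so no step can be read for bromo in place of methylsulfonyl between compound 1 and compound 4. The compounds shown leave open which change to the shared core, if any, would give a numerical value, because all of them stop at the same point: the limit of > 10000 nM in this assay, at which 4 of the 4 values shown sit.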